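The source may report more compounds than this note shows. Statements on the series, on what has been measured and on what is new or still open speak of the compounds shown alone.

In a functional assay on Rec1 cells (Homo sapiens) for inhibition, read by luminescence and CellTiter-Glo, with a stated time of 72 h (on this read-out higher numbers stand for weaker inhibition and lower numbers for stronger inhibition), compound 1 `O=C(CCl)N1CCCC(n2nc(-c3ccc(Oc4ccccc4)cc3)cc2CO)C1` gives 400 nM as the lowest of three numbers. Compound 4 `CCOC(=O)c1cc(-c2ccc(Oc3ccccc3)cc2)nn1C1CCCN(C(=O)CCl)C1` has ethoxycarbonyl in place of hydroxymethyl on an aromatic carbon and is otherwise the same as compound 1. Going by the values given here, no measured step covers this swap. The only one is a 4.7-fold higher number from compound 2 to compound 3 (0.67 log units; beyond the scatter) and it lies elsewhere, on a carbonyl carbon. Compound 2 `C=CC(=O)Nc1ccc(Cn2nc(-c3ccc(Oc4ccccc4)cc3)cc2C(=O)OCC)cc1` at 2800 nM and compound 3 `C/C=C/C(=O)Nc1ccc(Cn2nc(-c3ccc(Oc4ccccc4)cc3)cc2C(=O)OCC)cc1` at 13100 nM already carry ethoxycarbonyl and both sit higher than compound 1, though they also differ from it in other places. A modest rise is therefore expected in this assay with the estimated 2.5-fold higher number from compound 1 to compound 4 (0.40 log units; beyond the scatter) meaning weaker inhibition. Compound 4 is estimated at 1000 nM with an expected range from 250 nM to 4000 nM as the likely span of a measurement.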

Compound 4, half-maximal inhibitory concentration: 400 nM
Beside the measured number, compound 4's estimate is 2.5-fold (0.40 log units) above it, and the stated range covers the measured number.
By their numbers in this assay, from the lowest: compounds 1 and 4 (each within the scatter of the next); then compound 2; then compound 3.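

In this assay, going by these compounds alone, putting ethoxycarbonyl in place of hydroxymethyl on this aromatic carbon gives no change at the digits printed from compound 1 to compound 4 (within the scatter), the first measured step at this position. The group grows from 2 heavy atoms to 5 and loses its hydrogen-bond donor, yet the potency reading stays within the scatter. Nothing available explains why this swap leaves the number in place.

As far as these compounds go, whether a carboxylic acid, a primary amide or an aminomethyl group at this position would also leave the number in place remains open. So does whether a longer ester chain would.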